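The source may hold more compounds than are shown below. What is called first, only, known or untested is meant among the compounds shown, and "the series" means these compounds.

In a functional assay on HeLa S3 cells (Homo sapiens) for antiproliferative activity, read by XTT assay, with a stated time of 72 h (a higher number here means a weaker inhibitor, a lower number a stronger inhibitor), compound 1 (`C#Cc1cn([C@@H]2O[C@H](CO)[C@@H](O)[C@H]2O)c2ncnc(SC)c12`) gives 110 nM and compound 2 (`CNc1ncnc2c1c(-c1ccco1)cn2[C@@H]1O[C@H](CO)[C@@H](O)[C@H]1O`) gives 5000 nM. Compound 3 (`Nc1nc2c(c(-c3ccco3)cn2[C@@H]2O[C@H](CO)[C@@H](O)[C@H]2O)c(=O)[nH]1`) gives > 20000 nM, and this is a limit of the assay, not a number. From the compounds shown here alone, it is the only one of the three measured compounds that stands at a limit, so its true position on the scale remains open.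

Compound 4 (`Nc1nc2c(c(-c3cccs3)cn2[C@@H]2O[C@H](CO)[C@@H](O)[C@H]2O)c(=O)[nH]1`) keeps the core of compound 3 and changes one group, with thiophen-2-yl in place of furan-2-yl on an aromatic carbon. Among the compounds with values here, no pair of measured compounds shows this exchange, so the data offer no direct guide to its size. In this assay, no change beyond the usual scatter is expected, and no direction is favoured. The expected step is a number no higher from compound 3 to compound 4 (the limit leaves the size open). Compound 4 is therefore expected to remain weak and may well also reach the limit of the assay. For compound 4 the estimated half-maximal inhibitory concentration is 20000 nM, within an expected range of 6000 nM to 40000 nM.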

Compound 4, half-maximal inhibitory concentration: > 20000 nM
Compound 4: a limit, no number (the forecaster's own chance of this, stated with the estimate: 65%); the middle value lies on the limit itself.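

Within the data shown here, compound 3 and compound 4 both stand at a limit of this assay, not at a number, so no step between them can be read: the limit of > 20000 nM in this assay, at which 2 of the 4 values shown sit. The compounds shown leave open the true values of both compounds, and so whether thiophen-2-yl and furan-2-yl differ at all.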